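The source may hold more compounds than are shown below. What is called first, only, known or untested is meant among the compounds shown, and "the series" means these compounds.

Three esters built on one shared core have been tested in an ADME assay on HepG2 cells (Homo sapiens) for cytotoxicity, read by neutral red uptake, with a stated time of 24 h; a lower number here means a stronger inhibitor, a higher number a weaker inhibitor. Compound 1 `CC(C)c1cc2c3c(c1OC(=O)CCl)OC(=O)[C@@]31CCCC(C)(C)[C@@H]1CC2`, with a short chloro-bearing ester, gives 203000 nM. Compound 2 `CCCCCCCCCCCC(=O)Oc1c(C(C)C)cc2c3c1OC(=O)[C@@]31CCCC(C)(C)[C@@H]1CC2`, with a longer chain, gives > 1000000 nM, which is a limit of the assay and not a number. Compound 3 `CCCCCCCCCCCCCCCC(=O)Oc1c(C(C)C)cc2c3c1OC(=O)[C@@]31CCCC(C)(C)[C@@H]1CC2`, with a longer chain still, gives > 1000000 nM, again only a limit. Compound 3 therefore stands at the limit of > 1000000 nM in this assay, at which 2 of the 3 values shown sit.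

The next structure, compound 4 `CC(C)c1cc2c3c(c1OC(=O)CCCc1c[nH]c4ccccc14)OC(=O)[C@@]31CCCC(C)(C)[C@@H]1CC2`, differs from it at one place: 1H-indol-3-yl in place of dodecyl on a saturated chain carbon, three bonds along the chain from a carbonyl carbon. Here 1H-indol-3-yl stands in place of dodecyl, on a saturated chain carbon, three bonds along the chain from a carbonyl carbon.

Among the measured compounds shown here, two measured steps bear on this change. Decyl in place of chloro gave an at least 4.9-fold higher number from compound 1 to compound 2 (0.69 log units; beyond the scatter), while adding butyl to the chain gave a step that the two limits leave unreadable from compound 2 to compound 3. Only the first can be read, so compound 4, without the dodecyl, is expected to fall back only part of the way towards compound 1, on the strength of an at least 4.9-fold higher number from compound 1 to compound 2 (0.69 log units; beyond the scatter).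

The expected change is an at least 2.0-fold lower number from compound 3 to compound 4 (0.30 log units; that floor lies within the scatter), and the assay may again report only a limit. For compound 4 the estimated value in this assay is 500000 nM, with an expected range from 150000 nM to 1500000 nM.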

Compound 4, half-maximal inhibitory concentration: 120000 nM
The estimate for compound 4 lay 4.2-fold (0.62 log units) above the measured number; measured number outside the range, below it.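

In this assay, an ester with 1H-indol-3-yl on its chain gives a measured number, which the long alkyl esters do not: 1H-indol-3-yl in place of dodecyl gives an at least 8.3-fold lower number from compound 3 to compound 4 (0.92 log units; beyond the scatter), and in place of octyl it gives an at least 8.3-fold lower number from compound 2 to compound 4 (0.92 log units; beyond the scatter). Against the short chloro-bearing ester, the same comparison gives a 1.7-fold lower number from compound 1 to compound 4 (0.23 log units; within the scatter), so a chain ending in this ring group stays level with that ester rather than reaching the limit. Compound 2 and compound 3 remain at a limit of the assay, not a number: the limit of > 1000000 nM in this assay, at which 2 of the 4 values shown sit.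

On these data alone, it remains open whether the readable value follows from the 1H-indol-3-yl group itself or simply from the loss of the long alkyl chain. A phenyl group or an amine at the same place on the chain would help to separate the two.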